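Methylating the ring amine of a bridged pyridyl ligand

The source may report more compounds than this note shows. Statements on the series, on what has been measured and on what is new or still open speak of the compounds shown alone.

Measured so far in an in vitro assay on SH-SY5Y cells for displacement of a labelled ligand from Neuronal acetylcholine receptor; alpha3/beta4 (Homo sapiens); a higher number here means a weaker inhibitor, a lower number a stronger inhibitor:
- compound 1 `Clc1ccc(C2=CC3CNCC(C2)C3)cn1`, giving 6.2 nM
- compound 2 `Fc1ccc(C2=CC3CNCC(C2)C3)cn1`, giving 28 nM

Among the measured compounds shown here, compound 2 gives the higher of the two numbers; the single measured step is a 4.5-fold higher number from compound 1 to compound 2 (0.65 log units; beyond the scatter). The next compound, compound 3 `CN1CC2C=C(c3ccc(F)nc3)CC(C2)C1`, keeps the fluorinated pyridine of compound 2 and differs only in methyl in place of hydrogen on an amine nitrogen in a ring, that is, a methyl on the amine nitrogen in a ring of the six-membered non-aromatic ring with one nitrogen that belongs to the bridged two-ring system. For the measured compounds named here, the single measured step, the halogen exchange from compound 1 to compound 2, concerns the aromatic ring and says nothing about the amine; there is no measured step that bears on this change. Compound 3 is therefore expected to show a step of a 1.6-fold higher number from compound 2 to compound 3 (0.21 log units; within the scatter) in this assay, small and of uncertain direction. The estimate for compound 3 is 45 nM, with a range of 12 nM to 170 nM.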

Compound 3, inhibition constant: 1310 nM
The estimate for compound 3 lay 29-fold (1.46 log units) below the measured number; measured number outside the range, above it.
By their numbers in this assay, from the lowest: compound 1; then compound 2; then compound 3.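

In this assay, the amine nitrogen in a ring turns out to be a sensitive position, which the halogen exchange on the aromatic ring could not reveal: methyl in place of hydrogen there gives a 47-fold higher number from compound 2 to compound 3 (1.67 log units; beyond the scatter). This large step comes from the change of a single heavy atom, and it exceeds the other step in the series, a 4.5-fold higher number from compound 1 to compound 2 (0.65 log units; beyond the scatter). No measurement shown here accounts for the size of the step.

The compounds shown leave open whether methyl on this nitrogen gives a step of similar size when the pyridine carries chloro, as in compound 1. They also leave open how an ethyl group, a longer chain or an acetyl group on the same nitrogen would compare with methyl.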